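The compounds below may be only part of what the source reports. "The series", "measured", "known", "first", "only" and "open" are said of these compounds alone.

Working notes on the series. In an assay on cells for displacement of a labelled ligand from Glucagon receptor (Homo sapiens), in the presence of a further agent that is not named here (a lower number here means a stronger inhibitor, a higher number a weaker inhibitor), compound 1 `CCCC(Oc1ccc(-n2cc(C(=O)N(C)C)cn2)cc1)c1ccc(C(=O)NCCC(=O)O)cc1` gives 6500 nM, compound 2 `CCCC(Oc1ccc(-n2cc3c(n2)CCCC3)cc1)c1ccc(C(=O)NCCC(=O)O)cc1` gives 690 nM, and compound 3 `CCCC(Oc1ccc(-n2cc(F)cn2)cc1)c1ccc(C(=O)NCCC(=O)O)cc1` gives 1700 nM. Compound 3 therefore stands second highest of the three numbers: the step of a 3.8-fold lower number from compound 1 to compound 3 (0.58 log units; beyond the scatter) and the step of a 2.5-fold higher number from compound 2 to compound 3 (0.39 log units; beyond the scatter) both lie beyond the scatter. Compound 4 `CCCC(Oc1ccc(-n2cc(C)cn2)cc1)c1ccc(C(=O)NCCC(=O)O)cc1` differs from compound 3 by methyl in place of fluoro on an aromatic carbon. For the measured compounds named here, no measured step exchanges fluoro for methyl directly. The step of a 9.4-fold lower number from compound 1 to compound 2 (0.97 log units; beyond the scatter) shows a fused carbon ring on the five-membered aromatic ring giving a lower number than dimethylcarbamoyl, and the step of a 2.5-fold higher number from compound 2 to compound 3 (0.39 log units; beyond the scatter) shows fluoro sitting above that fused ring. A small move toward a lower number is therefore expected in this assay, about a 1.7-fold lower number from compound 3 to compound 4 (0.23 log units; within the scatter). Compound 4 is estimated at 1000 nM, within a range of 400 nM to 2500 nM.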

Compound 4, inhibition constant: 1900 nM
Beside the measured number, compound 4's estimate is 1.9-fold (0.28 log units) below it; the range from low to high includes it.
By their numbers in this assay, from the lowest: compound 2; then compounds 3 and 4 (each within the scatter of the next); then compound 1.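

On the change from 4-fluoro-1H-pyrazol-1-yl to 4-methyl-1H-pyrazol-1-yl, [ a 1.1-fold higher number from compound 3 to compound 4 (0.05 log units; within the scatter) ] shows that methyl and fluoro cannot be told apart at this position in this assay. Methyl also keeps the place fluoro held among the others: [ a 3.4-fold lower number from compound 1 to compound 4 (0.53 log units; beyond the scatter) ] runs toward a lower number, while [ a 2.8-fold higher number from compound 2 to compound 4 (0.44 log units; beyond the scatter) ] runs toward a higher one. Nothing available accounts for this equivalence.

From the compounds shown here alone, whether an amine, a nitrile or a longer alkyl chain at this position would stay with methyl and fluoro or come nearer compound 2 remains open.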